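Bromo on the imine-bearing phenyl of compound 2

A few compounds are considered here, and "the series" means these few. Any claim that something is new, unique, unknown or untested is made for them only; others in the source may bear on it.

The series shares one core, varied at the aryl group on the carbon with a double bond to nitrogen and at the aryl group beside the methyl-bearing carbon. Compound 1 `COc1ccc2cc(C(C)c3nnc4n3N=C(c3ccc([N+](=O)[O-])cc3)CS4)ccc2c1` gives 15100 nM in a functional assay on HCT-116 cells (Homo sapiens) for inhibition, read by sulforhodamine B assay, with a stated time of 72 h; on this read-out higher numbers stand for weaker inhibition and lower numbers for stronger inhibition. Compound 3 `COc1ccc2cc(C(C)c3nnc4n3N=C(c3ccc(Cl)cc3Cl)CS4)ccc2c1` gives 14000 nM, and the change a 1.1-fold lower number from compound 1 to compound 3 (0.03 log units; within the scatter) shows that swapping the aryl on that carbon moved the number little. Compound 2 `CC(c1ccc(-c2ccccc2)c(F)c1)c1nnc2n1N=C(c1ccccc1)CS2` gives 9700 nM; the values of compound 1 and compound 3 both lie within the scatter of it, so no ordering among the three is established.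

Compound 4 `CC(c1ccc(-c2ccccc2)c(F)c1)c1nnc2n1N=C(c1ccc(Br)cc1)CS2` differs from compound 2 by bromo in place of hydrogen on an aromatic carbon. Among the measured compounds shown here, the only measured step that bears on this position is the aryl exchange from compound 1 to compound 3, which stayed within the scatter; no measured pair isolates a single halogen at this site. The expectation is therefore a step of a 1.1-fold lower number from compound 2 to compound 4 (0.03 log units; within the scatter), with no change beyond the scatter in this assay. Compound 4 is estimated at 9000 nM, between 4000 nM and 20000 nM.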

Compound 4, half-maximal inhibitory concentration: 7100 nM
Estimate against measurement, compound 4: 1.3-fold (0.10 log units) above; measured number inside the range.
By their numbers in this assay, from the lowest: compounds 4, 2, 3 and 1 (each within the scatter of the next, the first and the last beyond it).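

Bromo in place of hydrogen, on an aromatic carbon para to a large group, gives a 1.4-fold lower number from compound 2 to compound 4 (0.14 log units; within the scatter) in this assay. This isolates a single-atom change on the aryl group at the carbon with a double bond to nitrogen, which the earlier aryl exchange did not do, and phenyl to 4-bromophenyl leaves the number within the scatter. The exchange of a 1.1-fold lower number from compound 1 to compound 3 (0.03 log units; within the scatter) also stays within the scatter, so neither change at this aryl group separates its pair, and no measurement at hand accounts for the size of the new step.

Going by these compounds, whether an amine or a carboxylic acid at this ring carbon would move the number beyond the scatter remains open. No pair shown isolates a change at the aryl group on the methyl-bearing carbon, so the contribution of that site also remains open.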